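Exchanging the Amine at the End of the Side Chain

The compounds below may be only part of what the source reports. "The series", "measured", "known", "first", "only" and "open" are said of these compounds alone.

Compound 2 `CCN(CC)CCCOc1c(OCc2ccccc2)cc(O)c2c(=O)cc(-c3ccccc3)oc12` was tested in a functional assay on MCF7 cells (Homo sapiens) for cytotoxicity, read by MTT assay, with a stated time of 72 h (a higher number here means a weaker inhibitor, a lower number a stronger inhibitor), where compound 2 gives 3210 nM. Compound 1 `COc1c(OCCCCN2CCN(C)CC2)cc(O)c2c(=O)cc(-c3ccc(Cl)cc3)oc12` gives 3210 nM in this assay, so compound 2 stands level with compound 1 at the digits reported, a difference that lies within the scatter of repeated measurements. Compound 3 `CN1CCN(CCCCOc2c(OCc3ccccc3)cc(O)c3c(=O)cc(-c4ccccc4)oc23)CC1` differs from compound 2 in one place: (4-methylpiperazin-1-yl)methyl in place of diethylamino on a saturated chain carbon, three bonds along the chain from an oxygen on an aromatic ring. For the measured compounds named here, no pair among the measured compounds shows this exchange on its own, so the two measured values give no direct guide to its size. The two measured compounds differ in several places at once and still sit at the same number, and nothing seen so far points in either direction. Compound 3 is therefore expected to stay close to compound 2, with a step of a 1.0-fold lower number from compound 2 to compound 3 (0.00 log units; within the scatter) that remains within the scatter. The estimate for compound 3 is 3200 nM, expected to fall between 1100 nM and 9500 nM.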

Compound 3, half-maximal inhibitory concentration: 2930 nM
For compound 3 the middle estimate is 1.1-fold (0.04 log units) above the measured one; the measured number falls inside the stated range.
By their numbers in this assay, from the lowest: compounds 3, 1 and 2 (each within the scatter of the next).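

In this assay, the exchange of diethylamino for (4-methylpiperazin-1-yl)methyl gives a 1.1-fold lower number from compound 2 to compound 3 (0.04 log units; within the scatter). For the compounds shown here, this is the first pair of compounds that differ in one place, so this exchange can now be read on its own, without other differences in the structure blurring it. Cut one bond further out, the same difference reads 3-(diethylamino)propyl to 4-(4-methylpiperazin-1-yl)butyl, and at this position a six-membered non-aromatic ring with 2 hetero atoms at the end of the chain reads the same as the open diethylamino group, within the scatter. Nothing measured here bears on this result.

From the compounds shown here alone, it remains open whether a morpholine, a primary amine or a carboxylic acid at the end of the chain would read differently. Going by these compounds, a shorter chain carrying the same 4-methylpiperazin-1-yl group also remains open.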